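Naphthyl on the ring amide nitrogen of compound 1

This account rests on a few compounds, and the source may have more. Where it says the series, first, only, none or still open, it means among the compounds named here.

Compound 1 `Cn1cc(C2=C(c3n[nH]c4ncccc34)C(=O)NC2=O)c2ccccc21` is the parent of this small set, bearing a hydrogen on the aromatic nitrogen and a hydrogen on the amide-type nitrogen in the ring. In a functional assay on K562 cells (Homo sapiens) for antiproliferative activity, read by MTT assay, with a stated time of 48 h (on this read-out lower numbers stand for stronger inhibition and higher numbers for weaker inhibition), compound 1 sits at the limit > 100000 nM, a limit of the assay and not a number. Compound 2 `Cn1cc(C2=C(c3nn(CCn4ccnc4)c4ncccc34)C(=O)NC2=O)c2ccccc21` likewise sits at a limit: in this assay compound 2 gives > 100000 nM. Among the compounds with values here, compound 3 `CN(C)CCCn1nc(C2=C(c3cn(C)c4ccccc34)C(=O)NC2=O)c2cccnc21` is the only member with a number, giving 50400 nM in this assay. The measured steps all concern the aromatic nitrogen: a step that the two limits leave unreadable from compound 1 to compound 2, an at least 1.9-fold lower number from compound 1 to compound 3 (0.29 log units; that floor lies within the scatter) and an at least 1.9-fold lower number from compound 2 to compound 3 (0.29 log units; that floor lies within the scatter). Two of the three values sit at the limit (the limit of > 100000 nM in this assay, at which 2 of the 3 values shown sit), so the series gives little to read from.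

Compound 4 `Cn1cc(C2=C(c3n[nH]c4ncccc34)C(=O)N(c3cccc4ccccc34)C2=O)c2ccccc21` differs from compound 1 in naphthalen-1-yl in place of hydrogen on an amide-type nitrogen in a ring. Within the data shown here, no measured step touches the amide-type nitrogen in the ring, so no step bears on this change, and compound 1 itself offers only a limit as a starting point. Compound 4 is therefore expected to stay near that limit, with a number no higher from compound 1 to compound 4 (the limit leaves the size open) as the estimated step. The estimate for compound 4 in this assay is 100000 nM, expected within 30000 nM to 300000 nM.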

Compound 4, half-maximal inhibitory concentration: > 100000 nM
Compound 4 was reported as a limit (the forecaster's own chance of this, stated with the estimate: 75%); the middle value sits exactly at the limit.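

In this assay compound 4 gives > 100000 nM, a limit of the assay and not a number. With compound 1 also at a limit, no step can be read between compound 1 and compound 4: the limit of > 100000 nM in this assay, at which 3 of the 4 values shown sit. The compounds shown leave open whether naphthalen-1-yl in place of hydrogen on the amide-type nitrogen in the ring changes the antiproliferative read-out at all.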